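The compounds below may be only part of what the source reports. "The series", "measured", "known", "first", "only" and "open" are said of these compounds alone.

Four compounds are compared here, and they rest on a shared core that is varied in only a few ways. Compound 1 `Cc1ccc(S(=O)(=O)N2C/C(=C\c3cccc(F)c3)C(=O)/C(=C/c3cccc(F)c3)C2)cc1` is the starting point. In a functional assay on HepG2 cells (Homo sapiens) for cytotoxicity, read by MTT assay, with a stated time of 24 h (a lower number here means a stronger inhibitor, a higher number a weaker inhibitor), compound 1 gives 3500 nM. Compound 2 `O=C1/C(=C/c2cccc(F)c2)CN(S(=O)(=O)c2ccc(O[N+](=O)[O-])cc2)C/C1=C\c1cccc(F)c1` differs from compound 1 in a single spot: nitrooxy in place of methyl on an aromatic carbon. On going from compound 1 to compound 2 this change produced a 2.3-fold higher number from compound 1 to compound 2 (0.36 log units; beyond the scatter), so the number rose, meaning weaker inhibition, by more than the usual scatter of the measurement. In this assay compound 2 gives 8100 nM.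

Compound 3 `Cc1ccc(S(=O)(=O)N2C/C(=C\c3ccc(F)cc3)C(=O)/C(=C/c3ccc(F)cc3)C2)cc1` has the same atoms as compound 1, joined differently; the difference between the two cores is not broken down here. In this assay compound 3 gives 4500 nM, which lies within the scatter of what compound 1 showed, so no order between the two can be claimed.

Compound 4 `O=C1/C(=C/c2ccc(F)cc2)CN(S(=O)(=O)c2ccc(O[N+](=O)[O-])cc2)C/C1=C\c1ccc(F)cc1` has not been measured yet. It stands to compound 3 exactly as compound 2 stands to compound 1: nitrooxy in place of methyl on an aromatic carbon. The change and its place are the same in both pairs, so it counts as the same change made on a second core. Because the first pair showed a 2.3-fold higher number from compound 1 to compound 2 (0.36 log units; beyond the scatter), a step of similar size is expected on going from compound 3 to compound 4, namely a 2.2-fold higher number from compound 3 to compound 4 (0.35 log units; beyond the scatter). Compound 4 is therefore estimated to give 10000 nM in this assay, with a likely range from 5000 nM to 20000 nM.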

Compound 4, half-maximal inhibitory concentration: 5400 nM
For compound 4 the middle estimate is 1.9-fold (0.27 log units) above the measured one; low and high end bracket the measured number.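

On the second core, the same swap of methyl for nitrooxy gave a 1.2-fold higher number from compound 3 to compound 4 (0.08 log units; within the scatter) in this assay, so on this core the change has no effect that the measurement can separate from scatter. Set beside the step on the first core, this one cannot be called different, since the gap between the two is no larger than repeated measurements would produce: the same change on two cores in this assay, a 2.3-fold higher number (0.36 log units; beyond the scatter) from compound 1 to compound 2 and a 1.2-fold higher number (0.08 log units; within the scatter) from compound 3 to compound 4, 1.9-fold (0.29 log units) apart, within the scatter of two such steps. The two pairs are therefore compatible with the change carrying over at a similar size, but they do not prove it, as only the first step stands clear of the scatter, and two pairs of compounds in a single cell assay say nothing firm about any further core.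

The compounds shown leave open how an amine or a carboxylic acid would compare with methyl and nitrooxy in that same place on the aromatic ring, which would help show whether this spot matters at all for the read-out. They also leave open whether the step would look the same on a core that carries chlorine in place of fluorine.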